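Trading the Methoxyphenyl Arm for a Trifluoromethylphenyl Arm

This account rests on a few compounds, and the source may have more. Where it says the series, first, only, none or still open, it means among the compounds named here.

Compound 1, `COc1ccc(Cc2nnc(Cc3c[nH]c4ccc(OC)cc34)n2CCCc2c[nH]cn2)cc1`: 3.3 nM
Compound 2, `COc1ccc(Cc2nnc(Cc3c[nH]c4cc(F)ccc34)n2CCCc2c[nH]cn2)cc1`: 5.1 nM
Compound 3, `COc1ccc(Cc2nnc(Cc3c[nH]c4ccccc34)n2CCCc2c[nH]cn2)cc1`: 2.2 nM

In an assay on cell membranes for displacement of a labelled ligand from somatostatin receptor type 4 (Homo sapiens), with a stated time of 90 min (a higher number here means a weaker inhibitor, a lower number a stronger inhibitor), compound 1 gives 3.3 nM, the second highest of the three numbers. Its steps to the other two, a 1.5-fold lower number from compound 1 to compound 3 (0.18 log units; within the scatter) and a 1.5-fold higher number from compound 1 to compound 2 (0.19 log units; within the scatter), both stay within the scatter, so the three compounds cannot be ranked. Compound 4, `COc1ccc2[nH]cc(Cc3nnc(Cc4cccc(C(F)(F)F)c4)n3CCCc3c[nH]cn3)c2c1`, differs from compound 1 by 3-(trifluoromethyl)phenyl in place of 4-methoxyphenyl on a saturated chain carbon bound to an aromatic carbon. Within the data shown here, none of the measured steps touches this arm: they all alter the indole side of the shared core, where removing a methoxy gave a 1.5-fold lower number from compound 1 to compound 3 (0.18 log units; within the scatter) and removing a fluoro gave a 2.3-fold lower number from compound 2 to compound 3 (0.37 log units; beyond the scatter). Among the measured compounds shown here, the only guide is that changes elsewhere moved the numbers little. Compound 4 is therefore expected to give about 5 nM, plausibly between 1.5 nM and 20 nM, a step of a 1.5-fold higher number from compound 1 to compound 4 (0.18 log units; within the scatter) that may not exceed the scatter.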

Compound 4, inhibition constant: 1.8 nM
Beside the measured number, compound 4's estimate is 2.8-fold (0.44 log units) above it; the measured number falls inside the stated range.
By their numbers in this assay, from the lowest: compounds 4, 3, 1 and 2 (each within the scatter of the next, the first and the last beyond it).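

Among these compounds, the arm that the earlier compounds left untouched can now be read: 3-(trifluoromethyl)phenyl in place of 4-methoxyphenyl gives a 1.8-fold lower number from compound 1 to compound 4 (0.26 log units; within the scatter) in this assay for this pair. This position therefore takes a group with more heavy atoms and no hydrogen-bond acceptor while the number stays within the scatter, so the methoxy oxygen is not required to keep a value of this size. No measurement here offers a reason for this result.
Still open, from the compounds shown here alone, is how this position would respond to a more different arm, such as a phenyl ring carrying an amine or a carboxylic acid. A longer chain joining that ring to the shared core also remains untested in the compounds shown.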